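A few compounds are considered here, and "the series" means these few. Any claim that something is new, unique, unknown or untested is made for them only; others in the source may bear on it.

Working notes on a small set of enaminone-bridged diaryl compounds, each carrying a secondary amine on the central chain. In a functional assay for inhibition, read by spectrophotometry, with a stated time of 30 min, tested at 1 uM (on this read-out lower numbers stand for less inhibition and higher numbers for more inhibition at the one concentration tested (going by the name of the read-out)), compound 1 `CCC(C)NC(=C\C(=O)/C=C/c1ccc(OC(C)=O)c(OC)c1)/C=C/c1ccc(OC(C)=O)c(OC)c1` gives 0% and compound 3 `O=C(/C=C(/C=C/c1ccc(O)cc1)NC1CCCCC1)/C=C/c1ccc(O)cc1` gives 0.03%. Compound 2 `C=CCNC(=C\C(=O)/C=C/c1ccc(O)c(OC)c1)/C=C/c1ccc(O)c(OC)c1` gives 0.1% in this assay; this is the highest of the three numbers, but its gap to compound 3 and its gap to compound 1 both fall within the scatter, so the three stand together as essentially no inhibition. Compound 4 `COc1cc(/C=C/C(=O)/C=C(/C=C/c2ccc(O)c(OC)c2)NCC(C)C)ccc1O` differs from compound 2 in one place: isopropyl in place of vinyl on a saturated chain carbon bound to an amine nitrogen. With all three measured compounds flat at the bottom of the read-out, no step beyond the scatter is expected from compound 2 to compound 4, and the expected step is no change at the digits printed from compound 2 to compound 4 (within the scatter). Compound 4 is therefore estimated at 0.1%, with a range of 0% to 5%.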

Compound 4, a percentage reported as inhibition, at one concentration (the size of the read-out at that concentration, not a potency): 0.09%
Compound 4: the middle estimate sits 0 percentage points above what was measured; measured number inside the range.
By their numbers in this assay, from the lowest: compounds 1, 3, 4 and 2 (each within the scatter of the next).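

In this assay, isopropyl in place of vinyl on a saturated chain carbon bound to an amine nitrogen gives the series its first single-place comparison: a number 0 percentage points lower from compound 2 to compound 4 (within the scatter). Losing the double bond at this position therefore leaves the read-out flat, though with both compounds at the bottom of the scale, this step cannot show whether the number would stay level with other changes at this position or in the rest of the series. Nothing available explains the flat read-out. Going by these compounds, whether a carboxylic acid or a longer chain at this position would lift the read-out remains open.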